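Cytotoxicity notes: from compound 2 to compound 3

A few compounds are considered here, and "the series" means these few. Any claim that something is new, unique, unknown or untested is made for them only; others in the source may bear on it.

In a toxicity assay on MT2 cells (Homo sapiens) for cytotoxicity (a higher number here means that more compound is tolerated, a lower number that less compound is tolerated), compound 1 `Cc1nc(C)c([C@H](OC(C)(C)C)C(=O)O)c(N2CCC(C)(C)CC2)c1C1=CCN(CCCc2ccc(F)cc2)CC1` gives >= 22000 nM, which is a limit of the assay and not a number. Going by the values given here, compound 2 `Cc1cccc(Cl)c1CN1CCc2cc(-c3c(C)nc(C)c([C@H](OC(C)(C)C)C(=O)O)c3N3CCC(C)(C)CC3)ccc2C1` gives 22500 nM, the only true number so far. Compound 3 `Cc1nc(C)c([C@H](OC(C)(C)C)C(=O)O)c(N2CCC(C)(C)CC2)c1-c1ccc2c(c1)CCN(Cc1cccc(F)c1C)C2` has 3-fluoro-2-methylphenyl in place of 2-chloro-6-methylphenyl on a saturated chain carbon bound to an amine nitrogen in a ring. Among the compounds with values here, no step between measured compounds exists to guide this change, and none beyond the scatter is expected in this assay. The estimated step is a 1.1-fold lower number from compound 2 to compound 3 (0.05 log units; within the scatter). For compound 3 the expected value is 20000 nM, within an estimated range of 9000 nM to 45000 nM.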

Compound 3, half-maximal cytotoxic concentration: >= 24000 nM
Compound 3 was reported as a limit (the forecaster's own chance of this, stated with the estimate: 35%); at least 1.2-fold (0.07 log units) between middle value and limit.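

On a saturated chain carbon bound to an amine nitrogen in a ring, 3-fluoro-2-methylphenyl in place of 2-chloro-6-methylphenyl gives an at least 1.0-fold higher number from compound 2 to compound 3 (0.02 log units; that floor lies within the scatter) in this assay. Going by these compounds alone, this is the first step read, and it shows no loss of tolerated concentration beyond the scatter for this change. The reading for compound 3 is a limit of the assay and not a number: the limit of >= 24000 nM in this assay, at which 1 of the 3 values shown sits.

From the compounds shown here alone, how far tolerance extends for compound 3 stays open. Also open, going by these compounds, is whether a benzyl carrying a nitrile or a methoxy group at this place would read the same.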